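Methyl to methoxy on the aryl ring, second pairing

A few compounds are considered here, and "the series" means these few. Any claim that something is new, unique, unknown or untested is made for them only; others in the source may bear on it.

Compound 1 `COC(=O)[C@H](CCSC)NC(=O)c1ccc(OC[C@H]2COc3ccccc3O2)cc1-c1ccccc1C` gives 6600 nM in a functional assay (HSMC cells, Homo sapiens) for antiproliferative activity, with a stated time of 72 h; a higher number here means a weaker inhibitor, a lower number a stronger inhibitor. Compound 2 `COC(=O)[C@H](CCSC)NC(=O)c1ccc(OC[C@H]2COc3ccccc3O2)cc1-c1ccccc1OC` carries methoxy in place of methyl on an aromatic carbon and gives 230000 nM in this assay; the step is a 35-fold higher number from compound 1 to compound 2 (1.54 log units; beyond the scatter). Compound 3 `COC(=O)[C@H](CC(C)C)NC(=O)c1ccc(OC[C@H]2COc3ccccc3O2)cc1-c1ccccc1C` differs from compound 1 by isopropyl in place of (methylsulfanyl)methyl on a saturated chain carbon, two bonds along the chain from an amide-type nitrogen and a carbonyl carbon; in this assay compound 3 gives 3000 nM, and the step is a 2.2-fold lower number from compound 1 to compound 3 (0.34 log units; beyond the scatter). Of the three measured, compound 3 holds the lowest number, with compound 2 furthest from it.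

Compound 4 `COC(=O)[C@H](CC(C)C)NC(=O)c1ccc(OC[C@H]2COc3ccccc3O2)cc1-c1ccccc1OC` is not yet measured in this assay. It differs from compound 3 by methoxy in place of methyl on an aromatic carbon, the same change, at the same place, that separates compound 2 from compound 1. That change is seen only once so far, so its carry-over onto the core of compound 3 rests on a single pairing. A step of about a 30-fold higher number from compound 3 to compound 4 (1.48 log units; beyond the scatter) from compound 3 to compound 4 is expected in this assay, because the earlier 35-fold higher number from compound 1 to compound 2 (1.54 log units; beyond the scatter) was large and well beyond scatter, with a little allowance for weaker transfer. Compound 4 is estimated at 90000 nM, with a likely span from 25000 nM to 300000 nM.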

Compound 4, half-maximal inhibitory concentration: 32000 nM
The estimate for compound 4 lay 2.8-fold (0.45 log units) above the measured number; low and high end bracket the measured number.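

In this assay, methoxy in place of methyl gives an 11-fold higher number from compound 3 to compound 4 (1.03 log units; beyond the scatter), the same direction as on the core of compound 1, but the size does not carry over unchanged: the same change on two cores in this assay, a 35-fold higher number (1.54 log units; beyond the scatter) from compound 1 to compound 2 and an 11-fold higher number (1.03 log units; beyond the scatter) from compound 3 to compound 4, 3.3-fold (0.51 log units) apart, beyond the scatter of two such steps

Isopropyl in place of (methylsulfanyl)methyl gives a 7.2-fold lower number from compound 2 to compound 4 (0.86 log units; beyond the scatter), again the same direction as in the earlier pairing, and again with a different size: the same change on two cores in this assay, a 2.2-fold lower number (0.34 log units; beyond the scatter) from compound 1 to compound 3 and a 7.2-fold lower number (0.86 log units; beyond the scatter) from compound 2 to compound 4, 3.3-fold (0.51 log units) apart, beyond the scatter of two such steps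

Both gaps come from the same four compounds, so they are one observation read from two sides: in this small set the direction of each change held while the two changes did not add independently, and this does not show why the sizes differ or how either step would run on a further core.

The compounds shown leave open whether a chlorine or an ethyl group on the same aromatic carbon would follow methyl or methoxy. They also leave open whether these steps hold with a carboxylic acid in place of the methyl ester.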